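A few compounds are considered here, and "the series" means these few. Any claim that something is new, unique, unknown or untested is made for them only; others in the source may bear on it.

Compound 1 `O=[N+]([O-])c1cn2c(n1)OC(COc1ccc(-c3ccc(C(F)(F)F)cc3)cn1)C2`: 45000 nM in an ADME assay on MRC5 cells (Homo sapiens) for cytotoxicity, read by fluorescence, with a stated time of 72 h; on this read-out lower numbers stand for stronger inhibition and higher numbers for weaker inhibition
Compound 2 `O=[N+]([O-])c1cn2c(n1)OC(COc1ccc(-c3ccc(C(F)(F)F)cc3)nc1)C2`: > 64000 nM, a limit of this assay
Compound 3 `CC1(COc2ccc(-c3ccc(C(F)(F)F)cc3)cn2)Cn2cc([N+](=O)[O-])nc2O1`: > 64000 nM, a limit of this assay

Compound 1 and compound 3 differ by methyl in place of hydrogen on a saturated ring carbon, and this change gave an at least 1.4-fold higher number from compound 1 to compound 3 (0.15 log units; that floor lies within the scatter). The difference between the cores of compound 1 and compound 2 is not broken down here. Compound 4 `CC1(COc2ccc(-c3ccc(C(F)(F)F)cc3)nc2)Cn2cc([N+](=O)[O-])nc2O1` is related to compound 2 by methyl in place of hydrogen on a saturated ring carbon, the same change at the same place as from compound 1 to compound 3. Two of the three values sit at the limit of > 64000 nM in this assay, at which 2 of the 3 values shown sit. Compound 2 is one of them, so its value in this assay is a limit rather than a number. The methyl step from compound 1 to compound 3 ended at that limit, and the step from compound 2 to compound 4 is therefore expected to stay at it, estimated as a step that the limit leaves unreadable from compound 2 to compound 4. Compound 4 is expected to give 90000 nM in this assay, most likely reported as a limit, within 50000 nM to 250000 nM.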

Compound 4, half-maximal inhibitory concentration: > 64000 nM
Compound 4: only a limit was reported; the forecaster's own chance of this, stated with the estimate: 85%; the middle value does not contradict the limit.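

Compound 2 and compound 4 both sit at a limit, so no step can be read between them: the limit of > 64000 nM in this assay, at which 3 of the 4 values shown sit. The compounds shown leave open whether methyl in place of hydrogen on a saturated ring carbon changes the number for compound 2 at all.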